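The compounds below may be only part of what the source reports. "The series", "measured", "known", "first", "only" and "open" are said of these compounds alone.

Compound 1 `Cc1cccc(C2(CNC(=O)Nc3c(C(C)C)cccc3C(C)C)CCCC2)c1`: 15 nM
Compound 2 `COC(=O)c1cccc(C2(CNC(=O)Nc3c(C(C)C)cccc3C(C)C)CCCC2)c1`: 34 nM

Of the two compounds measured in an assay on microsomes for inhibition of acyl-CoA:cholesterol acyltransferase (Oryctolagus cuniculus) (on this read-out higher numbers stand for weaker inhibition and lower numbers for stronger inhibition), compound 2 gives the higher number, 34 nM, with compound 1 at 15 nM; the gap between them is a 2.3-fold higher number from compound 1 to compound 2 (0.36 log units; beyond the scatter). Compound 3 `CC(C)c1cccc(C(C)C)c1NC(=O)NCC1(c2cccc(CO)c2)CCCC1` differs from compound 2 in one place: hydroxymethyl in place of methoxycarbonyl on an aromatic carbon. Among the measured compounds shown here, no measured pair shows this particular exchange; the only step on the same aromatic carbon is a 2.3-fold higher number from compound 1 to compound 2 (0.36 log units; beyond the scatter), a modest shift. A change of similar or smaller size is therefore expected for compound 3, in either direction, with the reading for compound 3 estimated at 30 nM (range 12 nM to 75 nM), a step of a 1.1-fold lower number from compound 2 to compound 3 (0.05 log units; within the scatter).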

Compound 3, half-maximal inhibitory concentration: 15 nM
Estimate against measurement, compound 3: 2.0-fold (0.30 log units) above; low and high end bracket the measured number.
By their numbers in this assay, from the lowest: compounds 1 and 3 (each within the scatter of the next); then compound 2.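

In this assay, hydroxymethyl in place of methoxycarbonyl gives a 2.3-fold lower number from compound 2 to compound 3 (0.36 log units; beyond the scatter), showing that this aromatic carbon can carry an oxygen-bearing group without the higher number seen with methoxycarbonyl. Against the methyl group, the added hydroxy gives no change at the digits printed from compound 1 to compound 3 (within the scatter), so of the three groups only methoxycarbonyl stands apart at this position. No evidence at hand bears on why the numbers fall this way. Going by these compounds, whether a carboxylic acid, an aminomethyl group or a hydroxyethyl chain on this carbon would read like hydroxymethyl or like methoxycarbonyl stays open.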